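Swapping methoxy for fluoro on the pendant phenyl ring

The source may report more compounds than this note shows. Statements on the series, on what has been measured and on what is new or still open speak of the compounds shown alone.

Measured compounds:
- compound 1, `O=C(Nc1ccc(Oc2ccnc3[nH]ccc23)cc1)c1cc(-c2ccc(F)cc2)ncn1`: 15900 nM
- compound 2, `O=C(Nc1ccc(Oc2ccnc3[nH]ccc23)c(F)c1)c1cc(-c2ccccc2)ncn1`: 4640 nM
- compound 3, `COc1ccc(-c2cc(C(=O)Nc3ccc(Oc4ccnc5[nH]ccc45)c(F)c3)ncn2)cc1`: 10400 nM

All three were tested in a functional assay on MCF7 cells (Homo sapiens) for cytotoxicity, read by MTT assay, with a stated time of 72 h; a higher number here means a weaker inhibitor, a lower number a stronger inhibitor. Compound 3 stands second highest of the three numbers, close to compound 1 and beyond the scatter above compound 2. Compound 4, `O=C(Nc1ccc(Oc2ccnc3[nH]ccc23)c(F)c1)c1cc(-c2ccc(F)cc2)ncn1`, differs from compound 3 by fluoro in place of methoxy on an aromatic carbon. Among the measured compounds shown here, the one step that bears on this position, a 2.2-fold higher number from compound 2 to compound 3 (0.35 log units; beyond the scatter), shows that putting methoxy onto the bare phenyl raised the number modestly. For the measured compounds named here, removing that methoxy again and placing fluoro there gives no measured step to lean on; compound 1, which carries the same 4-fluorophenyl without the ring fluorine, and compound 2 bracket the likely outcome. Compound 4 is therefore expected to land near or somewhat below compound 3, a step of a 1.3-fold lower number from compound 3 to compound 4 (0.11 log units; within the scatter), with an estimated value of 8000 nM in the range 3000 nM to 20000 nM.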

Compound 4, half-maximal inhibitory concentration: "not active" (no number reported)
Compound 4: no number reported, so the estimate cannot be set against anything.
By their numbers in this assay, from the lowest: compound 2; then compounds 3 and 1 (each within the scatter of the next).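

In this assay, among the compounds shown here, compound 4 is reported only as "not active", without a number, so no step from compound 3 to compound 4 can be read. Nothing shown explains this result. On these data alone, how far 4-methoxyphenyl to 4-fluorophenyl shifts the number stays open.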